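This account rests on a few compounds, and the source may have more. Where it says the series, first, only, none or still open, it means among the compounds named here.

Three compounds share one core and differ only in the group on one aromatic carbon. Compound 1 `CCN(CC)C(=O)c1ccc(S(=O)(=O)N2CCC[C@@H](C(=O)N3CCN(c4nc(C(C)C)no4)CC3)C2)cc1` carries a diethylcarbamoyl there; in an ADME assay on microsomes from liver (Homo sapiens) for metabolic stability, read by LC-MS, with a stated time of 60 min, tested at 10 uM (a lower number here means that the compound disappears faster, a higher number that the compound lasts longer), compound 1 gives 0.213 h. Compound 2 `CC(C)c1noc(N2CCN(C(=O)[C@@H]3CCCN(S(=O)(=O)c4ccc(S(=O)(=O)C(C)C)cc4)C3)CC2)n1` carries an isopropylsulfonyl instead. For compound 2 this assay reports only a limit, > 1 h, and the limit of > 1 h in this assay, at which 1 of the 3 values shown sits, marks that edge of the measurement. Compound 3 `CC(C)NS(=O)(=O)c1ccc(S(=O)(=O)N2CCC[C@@H](C(=O)N3CCN(c4nc(C(C)C)no4)CC3)C2)cc1` carries an isopropylsulfamoyl; in this assay compound 3 gives 0.056 h, the lowest of the two plain numbers, with compound 1 as its nearest neighbour, as the step of a 3.8-fold lower number from compound 1 to compound 3 (0.58 log units; beyond the scatter) shows. The other two steps are an at least 4.6-fold higher number from compound 1 to compound 2 (0.67 log units; beyond the scatter) and an at least 17-fold lower number from compound 2 to compound 3 (1.25 log units; beyond the scatter).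

Compound 4 `CCN(CC)S(=O)(=O)c1ccc(S(=O)(=O)N2CCC[C@@H](C(=O)N3CCN(c4nc(C(C)C)no4)CC3)C2)cc1` is reached by a change on the same sulfonyl sulfur: diethylamino in place of isopropylamino on a sulfonyl sulfur. The step that bears most directly on this position is an at least 17-fold lower number from compound 2 to compound 3 (1.25 log units; beyond the scatter), which was large; the step of a 3.8-fold lower number from compound 1 to compound 3 (0.58 log units; beyond the scatter) was modest. Neither step swaps one amino group for another, so the new step is read only loosely from them. A modest rise, not a large one, is expected for compound 4, as a 2.7-fold higher number from compound 3 to compound 4 (0.43 log units; beyond the scatter). The estimated half-life of compound 4 in this assay is 0.15 h, within a range from 0.06 h to 0.4 h.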

Compound 4, half-life: 0.0283 h
Estimate against measurement, compound 4: 5.3-fold (0.72 log units) above; the measured number lies below the stated range.
By their numbers in this assay, from the lowest: compounds 4 and 3 (each within the scatter of the next); then compound 1. At a limit, above all of these: compound 2.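

On the sulfonyl sulfur, diethylamino in place of isopropylamino gives a 2.0-fold lower number from compound 3 to compound 4 (0.30 log units; within the scatter), so this assay does not tell these two amino groups apart, even though the hydrogen-bond donor counted on isopropylamino is absent from diethylamino. Diethylamino in place of isopropyl on the same sulfur gives an at least 35-fold lower number from compound 2 to compound 4 (1.54 log units; beyond the scatter), and diethylsulfamoyl in place of diethylcarbamoyl on the aromatic carbon gives a 7.5-fold lower number from compound 1 to compound 4 (0.88 log units; beyond the scatter), so the short half-life first seen with one amino group on this sulfur appears again with a second one. The first of these two steps has a limit at one end, the entry for compound 2, and so gives a minimum size rather than an exact one: the limit of > 1 h in this assay, at which 1 of the 4 values shown sits.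

The compounds shown hold only isopropylamino and diethylamino as amino groups on this sulfur, so it stays open how a plain unsubstituted amino group or a methylamino group would read in this assay. Going by these compounds, it also stays open whether any group on this sulfur other than isopropyl would give a half-life closer to that of compound 2 than to that of compound 4.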